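The source may hold more compounds than are shown below. What is called first, only, known or untested is meant among the compounds shown, and "the series" means these compounds.

Measured so far in a functional assay on MKN-74 cells (Homo sapiens) for antiproliferative activity, with a stated time of 24 h; a lower number here means a stronger inhibitor, a higher number a weaker inhibitor:
compound 1, `NC(=O)c1c(NC(=O)c2ccccc2Cl)sc2c1CCN(C(=O)Nc1ccccc1Cl)C2`, 16300 nM;
compound 2, `NC(=O)c1c(NC(=O)c2ccccc2Cl)sc2c1CCN(C(=O)Nc1c(Cl)cccc1Cl)C2`, 24400 nM;
compound 3, `NC(=O)c1c(NC(=O)c2ccccc2)sc2c1CCN(C(=S)Nc1ccccc1Cl)C2`, 11800 nM.

Compound 3 gives the lowest of the three numbers, but its gap to compound 1 is within the scatter, and only the gap to compound 2 lies beyond it. From compound 2 to compound 1 the change is hydrogen in place of chloro on an aromatic carbon, and it made a step of a 1.5-fold lower number from compound 2 to compound 1 (0.18 log units; within the scatter). Compound 4, `NC(=O)c1c(NC(=O)c2ccccc2)sc2c1CCN(C(=S)Nc1ccccc1)C2`, is still to be measured in this assay. It differs from compound 3 by hydrogen in place of chloro on an aromatic carbon. This is the same kind of change as that from compound 2 to compound 1, though the surroundings differ: in compound 2 the leaving chloro also stands meta to a chloro group, which is not so in compound 3. How the cores of compound 3 and compound 2 differ is not broken down here. Resting on the step from compound 2 to compound 1 being within the scatter, compound 4 is expected to lie near compound 3, with an estimated step of a 1.2-fold lower number from compound 3 to compound 4 (0.09 log units; within the scatter). For compound 4 the estimate is 9500 nM, between 4000 nM and 25000 nM.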

Compound 4, half-maximal inhibitory concentration: > 50000 nM
Compound 4: no number, only a limit; the forecaster's own chance of this, stated with the estimate: 5%; middle value at least 5.2-fold (0.72 log units) from the limit.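

In this assay, hydrogen in place of chloro on an aromatic carbon gave an at least 4.2-fold higher number from compound 3 to compound 4 (0.62 log units; beyond the scatter), so this change did not carry over from one core to the other with the same outcome: the same change on two cores in this assay, a 1.5-fold lower number (0.18 log units; within the scatter) from compound 2 to compound 1 and an at least 4.2-fold higher number (0.62 log units; beyond the scatter) from compound 3 to compound 4, at least 6.3-fold (0.80 log units) apart, beyond the scatter of two such steps. Compound 4 gives > 50000 nM, which is a limit of the assay and not a number, so the step has a known lower bound but no known full size: the limit of > 50000 nM in this assay, at which 1 of the 4 values shown sits. The pair of steps shows that the result of removing this chloro cannot be read across these two cores, but it does not show which difference between the cores goes with the gap, nor how the change would behave on any further core.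

The compounds shown leave open whether a fluoro, methyl or methoxy group on that same aromatic carbon would give a value like that of compound 3. They also leave open how a carbonyl in place of the thiocarbonyl would read on the core of compound 3.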